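A longer chain on compound 3

The compounds below may be only part of what the source reports. "The series", "measured", "known", "first", "only" and "open" are said of these compounds alone.

In a functional assay on SH-SY5Y cells (Homo sapiens) for cytotoxicity, read by MTT assay, with a stated time of 72 h (on this read-out lower numbers stand for stronger inhibition and higher numbers for weaker inhibition), compound 1 `CC(C)[S+]([O-])CCCCN=C=S` gives 9420 nM, compound 2 `[O-][S+](CCCCN=C=S)Cc1ccccc1` gives 5210 nM and compound 3 `[O-][S+](CCCN=C=S)Cc1ccccc1` gives 8890 nM. Compound 3 thus lies within the scatter of both other compounds, and no order can be claimed for it. Compound 4 `[O-][S+](CCCCCCN=C=S)Cc1ccccc1` differs from compound 3 by a group of 6 heavy atoms (4 carbon, 1 nitrogen, 1 sulfur; no ring) in place of a group of 3 heavy atoms (1 carbon, 1 nitrogen, 1 sulfur; no ring), on a saturated chain carbon, three bonds along the chain from a sulfur. Among the compounds with values here, the only measured step that bears on this change is a 1.7-fold higher number from compound 2 to compound 3 (0.23 log units; within the scatter), which shortens the chain where compound 4 lengthens it, so a small shift toward a lower number in this assay is expected, not clearly beyond the scatter. The expected change is a 1.9-fold lower number from compound 3 to compound 4 (0.27 log units; within the scatter). Compound 4 is estimated at 4800 nM, with an expected range of 1800 nM to 9500 nM.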

Compound 4, half-maximal inhibitory concentration: 7630 nM
Compound 4: the middle estimate sits 1.6-fold (0.20 log units) below what was measured, within the range that was stated.
By their numbers in this assay, from the lowest: compounds 2, 4, 3 and 1 (each within the scatter of the next).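

In this assay lengthening the chain at this place gives a 1.2-fold lower number from compound 3 to compound 4 (0.07 log units; within the scatter) and, measured against the other benzyl-bearing compound, a 1.5-fold higher number from compound 2 to compound 4 (0.17 log units; within the scatter). Compounds 2, 3 and 4 therefore stay within the scatter of one another across these chain lengths, so no dependence on chain length can be read from them. Nothing measured here speaks to a cause for these numbers. On these data alone, whether a longer chain at this place would give a number beyond the scatter stays open, as does what a carboxylic acid there would give.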